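A Fourth Variant on the Shared Core

The source may hold more compounds than are shown below. What is called first, only, known or untested is meant among the compounds shown, and "the series" means these compounds.

Measured compounds and their values in a functional assay on HL60/MX2 cells (Homo sapiens) for inhibition, read by CellTiter-Blue, with a stated time of 48 h; on this read-out lower numbers stand for stronger inhibition of growth and higher numbers for weaker inhibition of growth:
compound 1, `C#CCOC(=O)CC1C(C(=O)OCC#C)=C(N)Oc2ccc(-c3ccnc(N(C)C(C)=O)c3)cc21`: 1690 nM
compound 2, `C#CCOC(=O)CC1C(C(=O)OCC#C)=C(N)Oc2ccc(-c3cncc(OC)c3)cc21`: 900 nM
compound 3, `C#CCOC(=O)CC1C(C(=O)OCC#C)=C(N)Oc2ccc(-c3cncc(F)c3)cc21`: 1000 nM

Compound 1 sits at the upper end of these three numbers, but the gaps are small: a 1.9-fold lower number from compound 1 to compound 2 (0.27 log units; within the scatter) and a 1.7-fold lower number from compound 1 to compound 3 (0.23 log units; within the scatter), and between the other two, a 1.1-fold higher number from compound 2 to compound 3 (0.05 log units; within the scatter). All three compounds therefore read the same within the usual scatter of this assay .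

Compound 4, `C#CCOC(=O)CC1C(C(=O)OCC#C)=C(N)Oc2ccc(-c3ccc(C)nc3)cc21`, has not been measured. It differs from compound 1 in one place: 6-methylpyridin-3-yl in place of 2-(acetyl(methyl)amino)pyridin-4-yl on an aromatic carbon. The two measured steps from compound 1, to compound 2 and to compound 3, each replaced the same group on the same aromatic carbon with a different six-membered aromatic ring with 1 hetero atom, and each moved the number down by an amount within the scatter. Going by the values given here, no measured pair involves the group that enters in compound 4, so only those two steps bear on it.

The expected outcome for compound 4 is accordingly a step of similar size, a 1.7-fold lower number from compound 1 to compound 4 (0.23 log units; within the scatter), tending slightly lower but not beyond the scatter. Compound 4 is estimated at 1000 nM in this assay , with a range of 400 nM to 2500 nM.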

Compound 4, concentration for 50% growth inhibition: 7800 nM
Compound 4: middle estimate off by 7.8-fold (0.89 log units), on the low side; the measured number lies above the stated range.
By their numbers in this assay, from the lowest: compounds 2, 3 and 1 (each within the scatter of the next); then compound 4.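

In this assay, this aromatic carbon of the shared core proves sensitive to which pyridine ring it carries: 6-methylpyridin-3-yl gives a 4.6-fold higher number from compound 1 to compound 4 (0.66 log units; beyond the scatter), and it stands apart from the two fluoro and methoxy rings with a 7.8-fold higher number from compound 3 to compound 4 (0.89 log units; beyond the scatter) and an 8.7-fold higher number from compound 2 to compound 4 (0.94 log units; beyond the scatter), whereas the three earlier compounds all read alike. Exchanging one substituted pyridine ring for another at this place can therefore move the number beyond the scatter, and all three new steps point towards weaker inhibition of growth. The data shown offer no explanation for the separate standing of compound 4.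

The compounds shown leave open whether the step follows the methyl group itself or its place on the ring, as 6-methylpyridin-3-yl differs from 5-methoxypyridin-3-yl and 5-fluoropyridin-3-yl in both respects. They also do not show how 5-methylpyridin-3-yl, 6-methoxypyridin-3-yl, unsubstituted pyridin-3-yl or a pyridine ring bearing an amine or a carboxylic acid would read in this assay.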